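The source may report more compounds than this note shows. Statements on the series, on what has been measured and on what is new or still open speak of the compounds shown alone.

Compound 1 `Cc1nnsc1C(=O)Nc1nc2ccccc2o1` gives 19600 nM in an ADME assay on HEK293 cells (Homo sapiens) for cytotoxicity, read by CCK-8 assay, with a stated time of 48 h; a higher number here means a weaker inhibitor, a lower number a stronger inhibitor. Among the three compounds measured so far, compound 1 stands second highest. Compound 2 `Cc1ccc2oc(NC(=O)c3snnc3C)nc2c1` gives 21900 nM in this assay, and the step of a 1.1-fold higher number from compound 1 to compound 2 (0.05 log units; within the scatter) lies within the scatter. Among the compounds with values here, compound 3 `Cc1nnsc1C(=O)Nc1nc2ccc(C(C)(C)C)cc2o1` gives 2420 nM in this assay; the step of an 8.1-fold lower number from compound 1 to compound 3 (0.91 log units; beyond the scatter) is the only step in the set that lies beyond the scatter.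

Compound 4 `O=C(Nc1nc2ccccc2o1)c1ccccc1` differs from compound 1 by phenyl in place of 4-methyl-1,2,3-thiadiazol-5-yl on a carbonyl carbon. Neither measured step bears directly on this change: both replace a hydrogen on the shared core, and the group on the carbonyl carbon is the same in all three measured compounds. Within the data shown here, there is thus no measured precedent for exchanging the ring on the carbonyl carbon, and the number has so far moved only in the step of an 8.1-fold lower number from compound 1 to compound 3 (0.91 log units; beyond the scatter), which concerns a different part of the molecule. For compound 4 no step beyond the scatter is expected, that is a 1.0-fold higher number from compound 1 to compound 4 (0.01 log units; within the scatter). The estimate for compound 4 is 20000 nM, with a range from 7000 nM to 55000 nM.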

Compound 4, half-maximal inhibitory concentration: > 100000 nM
Compound 4: a limit, no number; the forecaster's own chance of this, stated with the estimate: 25%; at least 5.0-fold (0.69 log units) between middle value and limit.
By their numbers in this assay, from the lowest: compound 3; then compounds 1 and 2 (each within the scatter of the next). At a limit, above all of these: compound 4.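

Replacing 4-methyl-1,2,3-thiadiazol-5-yl with phenyl on the carbonyl carbon gives, in this assay, an at least 5.1-fold higher number from compound 1 to compound 4 (0.70 log units; beyond the scatter), so the ring at this position can shift the number beyond the scatter. Within the data shown here, the only earlier step beyond the scatter, an 8.1-fold lower number from compound 1 to compound 3 (0.91 log units; beyond the scatter), lies on the shared core and runs the other way, so the two places move the number in opposite directions. The result for compound 4 is a limit, not a number, and the size of this step therefore stays open upward: the limit of > 100000 nM in this assay, at which 1 of the 4 values shown sits.

With one replacement ring shown, the compounds do not separate the role of the ring's hetero atoms from that of its methyl group. From the compounds shown here alone, how a pyridyl ring, an unsubstituted thiadiazole or an open alkyl chain on the carbonyl carbon would read remains open.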